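Esterifying the acid tail of compound 2: what cytotoxicity to expect

A few compounds are considered here, and "the series" means these few. Any claim that something is new, unique, unknown or untested is made for them only; others in the source may bear on it.

Three measured compounds share one core. Compound 1 `CC(C)N(Cc1cccc(OCCCCCC(=O)O)c1)C(=O)c1ccc(-c2ccncc2)cc1` carries a pyridin-4-yl group; in an ADME assay on HEK293 cells (Homo sapiens) for cytotoxicity, read by CellTiter-Glo and resazurin assay, with a stated time of 72 h (a higher number here means that more compound is needed for the effect, a lower number that less compound is needed), compound 1 reaches only the assay limit, > 26000 nM. Compound 2 `CC(C)Oc1cccc(-c2ccc(C(=O)N(Cc3cccc(OCCCCCC(=O)O)c3)C(C)C)cc2)c1` gives in this assay only a limit, > 26000 nM. Compound 3 `COc1cccc(-c2ccc(C(=O)N(Cc3cccc(OCCCCCC(=O)O)c3)C(C)C)cc2)c1` likewise gives only a limit, > 20900 nM. Because of the limit of > 26000 nM in this assay, at which 2 of the 3 values shown sit, and (the limit of > 20900 nM in this assay, at which 1 of the 3 values shown sits), the steps a step that the two limits leave unreadable from compound 1 to compound 2, a step that the two limits leave unreadable from compound 1 to compound 3 and a step that the two limits leave unreadable from compound 2 to compound 3 cannot be read, so compound 2 stands simply at the limit alongside the others. Compound 4 `CCOC(=O)CCCCCOc1cccc(CN(C(=O)c2ccc(-c3cccc(OC(C)C)c3)cc2)C(C)C)c1` differs from compound 2 by ethyl in place of hydrogen on an oxygen next to a carbonyl group. For the measured compounds named here, no measured step covers this change, so no direction is known. Compound 4 is expected to give about 26000 nM, within 8000 nM to 60000 nM, meaning an expected step of a number no higher from compound 2 to compound 4 (the limit leaves the size open).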

Compound 4, half-maximal effective concentration: > 26000 nM
Compound 4 gave a limit, no number; the forecaster's own chance of this, stated with the estimate: 65%; the middle value lies on the limit itself.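

Compound 2 and compound 4 both stand at a limit in this assay, so the step between them cannot be read: the limit of > 26000 nM in this assay, at which 3 of the 4 values shown sit.

The compounds shown leave open whether ethoxycarbonyl in place of carboxy changes cytotoxicity at all, and at what concentration any of them would show it.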